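Compound 4 Expected to Share the Limit of Compound 3

The source may hold more compounds than are shown below. What is called first, only, known or untested is meant among the compounds shown, and "the series" means these compounds.

Measured compounds:
Compound 1, `Cc1cccc(-n2nncc2CN2C(=O)C3(C(C#N)=C(N)Oc4c(N)cc5nc6ccccc6nc5c43)c3ccccc32)c1`, gives in a functional assay on MCF7 cells (Homo sapiens) for antiproliferative activity, read by MTT assay, with a stated time of 48 h (a higher number here means a weaker inhibitor, a lower number a stronger inhibitor), a value of > 50000 nM, which is a limit of the assay and not a number.
Compound 2, `CC(=O)Nc1ccc(-n2nncc2CN2C(=O)C3(C(C#N)=C(N)Oc4c(N)cc5nc6ccccc6nc5c43)c3ccccc32)cc1`, gives in this assay a value of > 50000 nM, again a limit.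
Compound 3, `CCc1cccc(CC)c1-n1nncc1CN1C(=O)C2(C(C#N)=C(N)Oc3c(N)cc4nc5ccccc5nc4c32)c2ccccc21`, gives in this assay a value of > 50000 nM, again a limit.

Compound 3 therefore stands at the same limit as the other two compounds, and no number places it above or below them. The steps from compound 1 to compound 2 a step that the two limits leave unreadable from compound 1 to compound 2, from compound 1 to compound 3 a step that the two limits leave unreadable from compound 1 to compound 3 and from compound 2 to compound 3 a step that the two limits leave unreadable from compound 2 to compound 3 cannot be read in size or direction because of the limit of > 50000 nM in this assay, at which 3 of the 3 values shown sit.

Compound 4, `Cc1cc(C)c(-n2nncc2CN2C(=O)C3(C(C#N)=C(N)Oc4c(N)cc5nc6ccccc6nc5c43)c3ccccc32)c(C)c1`, is the next compound to be tested. Its change from compound 3 is 2,4,6-trimethylphenyl in place of 2,6-diethylphenyl on an aromatic nitrogen. The three measured steps all concern the same aromatic nitrogen and none of them gave a readable size, so they suggest no movement away from the limit. The step from compound 3 to compound 4 is expected to be a step that the limit leaves unreadable from compound 3 to compound 4, which is no step beyond the scatter. Compound 4 is therefore estimated to give 80000 nM in this assay, with a range from 30000 nM to 300000 nM, and most likely only a limit will be reported.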

Compound 4, half-maximal inhibitory concentration: > 50000 nM
Compound 4 gave a limit, no number; the forecaster's own chance of this, stated with the estimate: 85%; the middle value lies beyond the limit too.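

Compound 4 gives a limit in this assay, as do compound 1, compound 2 and compound 3, so none of the steps from these three compounds to compound 4 can be read in size or direction, because all four sit at the same limit: (the limit of > 50000 nM in this assay, at which 4 of the 4 values shown sit).

The compounds shown leave open how these four rank and whether any group on this aromatic nitrogen gives a readable value in this assay.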